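Formyloxy to propanoyloxy: notes on the series

The source may hold more compounds than are shown below. What is called first, only, known or untested is meant among the compounds shown, and "the series" means these compounds.

Measured in a functional assay on the whole organism with Mus musculus as the target, in the maximal electroshock model; on this read-out higher numbers stand for an effect only at larger amounts of compound and lower numbers for an effect already at smaller amounts:
- compound 1 `OC1CCN(c2ccc(-c3cccc(C(F)(F)F)c3)nn2)CC1`: 63 mg/kg
- compound 2 `Cc1ccccc1-c1ccc(N2CCC(O)CC2)nn1`: 30 mg/kg
- compound 3 `O=COC1CCN(c2ccc(-c3ccc(Cl)cc3Cl)nn2)CC1`: 24 mg/kg

Compound 3 lies within the scatter of compound 2. Its number is lower than that of compound 1, with the gap beyond the scatter. Compound 4 `CCC(=O)OC1CCN(c2ccc(-c3ccc(Cl)cc3Cl)nn2)CC1` keeps the structure of compound 3 except for ethyl in place of hydrogen on a carbonyl carbon, which reads as formyloxy to propanoyloxy (ethyl in place of hydrogen on a carbonyl carbon). Among the measured compounds shown here, no measured pair shows this change, so the expectation rests on compound 3 at 24 mg/kg. In this assay the expected 1.2-fold higher number from compound 3 to compound 4 (0.07 log units; within the scatter) is small, with no change beyond the scatter. The estimate for compound 4 is 28 mg/kg, with an expected range from 13 mg/kg to 60 mg/kg.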

Compound 4, dose for half-maximal effect: 50 mg/kg
Estimate against measurement, compound 4: 1.8-fold (0.25 log units) below; the measured number falls inside the stated range.
By their numbers in this assay, from the lowest: compounds 3, 2, 4 and 1 (each within the scatter of the next, the first and the last beyond it).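

Among the compounds shown here, the first single-change step comes at this position: in this assay, ethyl in place of hydrogen on a carbonyl carbon gives a 2.1-fold higher number from compound 3 to compound 4 (0.32 log units; beyond the scatter), a modest step. The position is therefore not silent to this change, and formyloxy carries the lower number of the two groups. Nothing at hand bears on what lies behind the step.

Going by these compounds, how acetyloxy or the longer butanoyloxy would read on the same core stays open. So does whether an amine at this place would keep a number in this range.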